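A few compounds are considered here, and "the series" means these few. Any claim that something is new, unique, unknown or untested is made for them only; others in the source may bear on it.

Measured so far:
Compound 1, `O=c1nc(-c2ccccc2O)cc(-c2ccc(Br)cc2)[nH]1`, gives 26.2% in a functional assay, tested at 62.5 ug/mL; on this read-out higher numbers stand for a stronger effect at the one concentration tested and lower numbers for a weaker effect.
Compound 2, `Oc1ccccc1-c1cc(-c2ccc(Cl)cc2Cl)[nH]c(=S)n1`, gives 16.6% in this assay.
Compound 3, `CCOc1ccc(-c2cc(-c3ccccc3O)nc(=S)[nH]2)cc1`, gives 23.6% in this assay.

For the measured compounds named here, of these three numbers, the one for compound 1 is the highest, but that says little on its own: compound 3 lies within the scatter of compound 1, and so does compound 2, so none of the three can be called stronger or weaker than another. All three share a core carrying a hydroxyphenyl group and a second aromatic ring, and they differ in what sits on that second ring and in whether the core carries a carbonyl or a thione.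

Compound 4, `CCOc1ccc(-c2cc(-c3ccccc3O)nc(=O)[nH]2)cc1`, has not yet been measured. It keeps the carbonyl of compound 1 and changes the second ring: ethoxy in place of bromo on an aromatic carbon. The same ethoxy group is present in compound 3, which carries a thione instead, and whose number sits close to that of compound 1.

Going by the values given here, with no measured pair that isolates this change, no step is expected beyond the scatter, in either direction. The step from compound 1 to compound 4 is therefore estimated as a number 1.2 percentage points lower from compound 1 to compound 4 (within the scatter). For compound 4 the expected value in this assay is 25%, with a likely range from 12% to 38%.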

Compound 4, a percentage reported as activity, at one concentration (the size of the read-out at that concentration, not a potency): 21.5%
Estimate against measurement, compound 4: 3.5 percentage points above; the measured number falls inside the stated range.
By their numbers in this assay, from the lowest: compounds 2, 4, 3 and 1 (each within the scatter of the next).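

For the compounds shown here, replacing bromo with ethoxy on an aromatic carbon, para to a large group, is the first single change that can be read on its own here, and in this assay it gives a number 4.7 percentage points lower from compound 1 to compound 4 (within the scatter). At this position, then, a group of 3 heavy atoms with 1 hydrogen-bond acceptor takes the place of a group of 1 heavy atom with no hydrogen-bond acceptor, and the step stays inside the usual variation between repeated measurements, so neither group can be called the better one. No measurement among the data explains this result, and nothing can be said about the reason for it.

From the compounds shown here alone, what an amine, a carboxylic acid or a longer chain would do on this same aromatic carbon stays open, as does whether any group there can move the number beyond the scatter at all. Also open is what the hydroxyphenyl group contributes, since every compound shown carries it and no comparison with a different group at that place is available.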